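A few compounds are considered here, and "the series" means these few. Any claim that something is new, unique, unknown or untested is made for them only; others in the source may bear on it.

Three compounds have been measured so far in a functional assay on MCF7 cells (Homo sapiens) for inhibition, read by colorimetric assay and MTT assay, with a stated time of 72 h; on this read-out lower numbers stand for stronger inhibition and higher numbers for weaker inhibition

Compound 1 `C=CCCCCOc1ccccc1-c1cnc(OCCC=C)n1C` gives 8000 nM
Compound 2 `CCCCOc1ncc(-c2ccccc2OC)n1C` gives 55000 nM
Compound 3 `C#CCCCCOc1ncc(-c2ccccc2OC)n1C` gives 10000 nM

Compound 3 lies within the usual scatter of compound 1, and the numbers of both sit well under that of compound 2. The next compound, compound 4 `C=CCCOc1ncc(-c2ccccc2OC)n1C`, has not yet been measured. Compared with compound 3, its change is vinyl in place of but-3-yn-1-yl on a saturated chain carbon, two bonds along the chain from an oxygen on an aromatic ring and the same difference can be read as hex-5-yn-1-yl to but-3-en-1-yl. The chain therefore ends in a double bond instead of a triple bond.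

Within the data shown here, one measured step bears directly on this: a 5.5-fold lower number from compound 2 to compound 3 (0.74 log units; beyond the scatter) and it is modest but real. That step placed ethynyl in place of hydrogen on a saturated chain carbon, and compound 4 gives up this ethynyl end. Compound 1 also carries a (but-3-en-1-yl)oxy group and gives 8000 nM but it differs elsewhere too, so it is only a loose guide. Among the measured compounds shown here, no measured pair isolates the double-bond ending.

Part of the earlier gain is expected to be lost in this assay and the estimated step is a 2.8-fold higher number from compound 3 to compound 4 (0.45 log units; beyond the scatter) towards a higher number. For compound 4 the expected value is 28000 nM with an estimated range from 10000 nM to 70000 nM for now.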

Compound 4, half-maximal inhibitory concentration: 27000 nM
Compound 4: the middle estimate sits 1.0-fold (0.02 log units) above what was measured; low and high end bracket the measured number.
By their numbers in this assay, from the lowest: compounds 1 and 3 (each within the scatter of the next); then compound 4; then compound 2.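

In this assay, the chain on the oxygen responds to more than one kind of change. Vinyl in place of ethyl at this place gives a 2.0-fold lower number from compound 2 to compound 4 (0.31 log units; beyond the scatter), so a double bond at the chain end already counts for something, while replacing the hex-5-yn-1-yl chain with but-3-en-1-yl gives a 2.7-fold higher number from compound 3 to compound 4 (0.43 log units; beyond the scatter), so this double-bond chain does not match the longer triple-bond chain. The other ether also matters: hydrogen in place of pent-4-en-1-yl, on the saturated chain carbon bound to an oxygen on an aromatic ring, gives a 3.4-fold higher number from compound 1 to compound 4 (0.53 log units; beyond the scatter), a step of similar modest size, and no measurement here explains any of these steps.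

Chain length and chain ending change together from compound 3 to compound 4, so the compounds shown cannot say which of the two accounts for that step. A hex-5-en-1-yl chain or a but-3-yn-1-yl chain on this oxygen would separate them, and a chain ending in an amine or a carboxylic acid would test whether anything other than a carbon-carbon multiple bond can be tolerated there.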